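The source may report more compounds than this note shows. Statements on the series, on what has been measured and on what is new or still open speak of the compounds shown alone.

Working notes on the sulfonamide series.

Of the compounds shown here, three have been measured in a physicochemical assay for acid dissociation. Compound 1 `O=[N+]([O-])c1cccc(NS(=O)(=O)c2ccc(F)cc2)c1` gives 7.85 in this assay. Compound 2 `O=[N+]([O-])c1cccc(NS(=O)(=O)c2ccc(Cl)cc2)c1` gives 7.51 in this assay. Compound 3 `O=S(=O)(Nc1ccc(Cl)cc1)c1ccccc1` gives 8.75 in this assay, the highest of the three numbers, and its gaps to compound 1 and to compound 2 both lie beyond the usual scatter.

One single-point change is seen between measured compounds: fluoro in place of chloro on an aromatic carbon. The step is a number 0.34 log units higher from compound 2 to compound 1 (beyond the scatter).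

Compound 4 `O=S(=O)(Nc1ccc(F)cc1)c1ccccc1` has not yet been measured in this assay. It differs from compound 3 by the same change, (fluoro in place of chloro on an aromatic carbon). The difference between the core of compound 3 and the core of compound 2 is not broken down here.

Among the compounds with values here, for compound 4 the step of a number 0.35 log units higher from compound 3 to compound 4 (beyond the scatter) is expected, of about the size seen in a number 0.34 log units higher from compound 2 to compound 1 (beyond the scatter), resting on the single precedent of compound 2 and compound 1 and on the high value of compound 3, 8.75. Compound 4 is accordingly estimated at 9.1, between 8.75 and 9.45.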

Compound 4, acid dissociation constant: 8.85
Estimate against measurement, compound 4: 0.25 log units above; the range from low to high includes it.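

In this assay, fluoro in place of chloro on an aromatic carbon gave a number 0.34 log units higher from compound 2 to compound 1 (beyond the scatter) on the first core, but on the second it gave a number 0.10 log units higher from compound 3 to compound 4 (within the scatter), so the step seen beyond the scatter on the core of compound 1 is not reproduced beyond the scatter on the core of compound 4. This shows that the size of the step did not carry over reliably between these two cores, and that one precedent was a weak basis for transfer in this series; it does not show that the change never matters on the core of compound 4, and two pairs set no rule for other cores. Nothing at hand bears on why the two steps differ.

From the compounds shown here alone, the difference between the core of compound 2 and the core of compound 3 is not broken down, so which part of it goes with the difference between the two steps remains open. Only fluoro and chloro appear at the changed place, which leaves open how bromo, methoxy or an amine there would behave on either core.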